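The source may hold more compounds than are shown below. What is called first, only, known or untested is meant among the compounds shown, and "the series" means these compounds.

Measured compounds:
compound 1 `O=C(Nc1cccc(Cl)c1)c1cccc(Br)c1`: 51000 nM
compound 2 `O=C(Nc1ccc(Sc2nc3ccccc3s2)cc1)c1ccccc1`: > 100000 nM (a limit of the assay, not a number)
compound 3 `O=C(Nc1ccc(Sc2nc3ccccc3s2)cc1)c1ccccc1O`: 74000 nM

In an ADME assay on HEK293 cells (Homo sapiens) for cytotoxicity, read by reporter gene assay and resazurin assay, with a stated time of 48 h (a higher number here means that more compound is tolerated, a lower number that less compound is tolerated), compound 2 reaches only a limit, > 100000 nM; this is the case noted as the limit of > 100000 nM in this assay, at which 1 of the 3 values shown sits. The change hydroxy in place of hydrogen on an aromatic carbon gives an at least 1.3-fold lower number from compound 2 to compound 3 (0.13 log units; that floor lies within the scatter). Compound 1 has the lowest of the two numbers, and compound 3 sits nearest to it, within the scatter. The difference between the cores of compound 1 and compound 2 is not broken down here.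

Compound 4 `O=C(Nc1cccc(Cl)c1)c1cccc(Br)c1O` differs from compound 1 by hydroxy in place of hydrogen on an aromatic carbon. This is the same kind of change as between compound 2 and compound 3, but here the place is ortho to a bromo group as well as ortho to a large group. Resting on an at least 1.3-fold lower number from compound 2 to compound 3 (0.13 log units; that floor lies within the scatter), the step is expected to be a 1.3-fold lower number from compound 1 to compound 4 (0.11 log units; within the scatter). Compound 4 is therefore estimated at 40000 nM, between 20000 nM and 80000 nM.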

Compound 4, half-maximal cytotoxic concentration: 32000 nM
Compound 4: the middle estimate sits 1.3-fold (0.10 log units) above what was measured; the range from low to high includes it.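

In this assay, hydroxy in place of hydrogen on an aromatic carbon now stands on a second core, with a 1.6-fold lower number from compound 1 to compound 4 (0.20 log units; within the scatter). Set beside the earlier step, this gives no measurable gap between the two cores, but it does not show that the change carries over with one fixed size: the same change on two cores in this assay, an at least 1.3-fold lower number (0.13 log units; that floor lies within the scatter) from compound 2 to compound 3 and a 1.6-fold lower number (0.20 log units; within the scatter) from compound 1 to compound 4; the limit leaves it open whether they differ Compound 2 stands only at a limit of the assay, not at a number: the limit of > 100000 nM in this assay, at which 1 of the 4 values shown sits.

From the compounds shown here alone, an amine, a methoxy group or a carboxylic acid in the same place remains open on both cores. Also open, going by these compounds, is whether any replacement of that hydrogen gives a step beyond the scatter in this assay.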